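The source may hold more compounds than are shown below. What is called first, only, known or untested is meant among the compounds shown, and "the series" means these compounds.

Compound 1 `C=C[C@@](C)(/C=C/c1ccc(OCc2ccccc2)cc1)CCC=C(C)C` carries a benzyloxy group on an aromatic carbon of its core. In a functional assay on SEM cells (Homo sapiens) for cytotoxicity, with a stated time of 72 h (on this read-out higher numbers stand for an effect only at larger amounts of compound and lower numbers for an effect already at smaller amounts), compound 1 gives > 36600 nM, which is a limit of the assay and not a number. Compound 2 `C=C[C@@](C)(/C=C/c1ccc(O)c(/C=C/c2ccc(Cl)c(Cl)c2)c1)CCC=C(C)C` gives > 7500 nM in this assay, and this is also a limit. No true number is therefore available yet for either compound, and the two limits cannot be ranked. Compound 3 `C=C[C@@](C)(/C=C/c1ccc(Nc2ccc(F)cc2)cc1)CCC=C(C)C` keeps the core of compound 1 but has (4-fluorophenyl)amino in place of benzyloxy on an aromatic carbon, para to a large group: (4-fluorophenyl)amino in place of benzyloxy on an aromatic carbon. Within the data shown here, no measured step shows what such a swap does, so only a modest shift toward lower numbers is expected, and another limit is the likeliest result. The expected step of an at least 1.8-fold lower number from compound 1 to compound 3 (0.26 log units; that floor lies within the scatter) is small. For compound 3 the estimated value is 20000 nM, within an expected range of 6000 nM to 50000 nM.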

Compound 3, half-maximal effective concentration: > 36600 nM
Compound 3 gave a limit, no number (the forecaster's own chance of this, stated with the estimate: 70%); at least 1.8-fold (0.26 log units) between middle value and limit.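

Compound 1 and compound 3 each end in a limit and not a number, and the step between them cannot be read. The compounds shown leave open what (4-fluorophenyl)amino in place of benzyloxy does, and at what amount, if any, the shared core acts on these cells.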